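Triazolylmethyl spirooxindole series: weak antiproliferative numbers

The source may report more compounds than this note shows. Statements on the series, on what has been measured and on what is new or still open speak of the compounds shown alone.

Measured compounds so far:
compound 1, `Cc1ccccc1-n1nncc1CN1C(=O)C2(C(C#N)=C(N)Oc3c2c2nc4ccccc4nc2c2ccccc32)c2ccccc21`, > 50000 nM (a limit of the assay, not a number)
compound 2, `Cc1cccc(-n2nncc2CN2C(=O)C3(C(C#N)=C(N)Oc4c3c3nc5ccccc5nc3c3ccccc43)c3ccccc32)c1`, 39600 nM
compound 3, `CCc1ccccc1-n1nncc1CN1C(=O)C2(C(C#N)=C(N)Oc3c(N)cc4nc5ccccc5nc4c32)c2ccccc21`, 24600 nM

In a functional assay on A549 cells (Homo sapiens) for antiproliferative activity, read by MTT assay, with a stated time of 48 h (on this read-out higher numbers stand for weaker inhibition and lower numbers for stronger inhibition), compound 1 reaches only the limit of the assay, > 50000 nM; this is the case described in the limit of > 50000 nM in this assay, at which 1 of the 3 values shown sits. Compound 2 gives a number, 39600 nM, and the move an at least 1.2-fold lower number from compound 1 to compound 2 (0.10 log units; that floor lies within the scatter) stays within the scatter. Compound 3 gives 24600 nM, which sits within the scatter of the number for compound 2; of the two numbers shown, compound 3 is not separated from compound 2 beyond the scatter. The value of compound 1 is a limit of the assay.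

Compound 4, `Cc1ccc(Cl)cc1-n1nncc1CN1C(=O)C2(C(C#N)=C(N)Oc3c(N)cc4nc5ccccc5nc4c32)c2ccccc21`, differs from compound 3 in one place: 5-chloro-2-methylphenyl in place of 2-ethylphenyl on an aromatic nitrogen. Among the measured compounds shown here, the only measured step, an at least 1.2-fold lower number from compound 1 to compound 2 (0.10 log units; that floor lies within the scatter), concerns a different exchange on the same aromatic nitrogen and was itself within the scatter, so it bears only loosely on the change from compound 3 to compound 4. No step beyond the scatter is therefore expected in this assay; the step of a 1.1-fold lower number from compound 3 to compound 4 (0.05 log units; within the scatter) is the estimate. Compound 4 is expected to give about 22000 nM in this assay, with a range from 8000 nM to 50000 nM.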

Compound 4, half-maximal inhibitory concentration: > 50000 nM
Compound 4 gave a limit, no number (the forecaster's own chance of this, stated with the estimate: 20%); at least 2.2-fold (0.35 log units) between middle value and limit.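

Compound 4 stands at a limit of this assay, not at a number. Exchanging 2-ethylphenyl for 5-chloro-2-methylphenyl on this aromatic nitrogen gives an at least 2.0-fold higher number from compound 3 to compound 4 (0.30 log units; that floor lies within the scatter), so the size of the step remains undefined and the printed floor does not establish a separation beyond the scatter. Unlike the earlier step at this position, this change keeps the core of compound 3 and the heavy-atom count of the aryl group, yet the result is a limit rather than a number, and the limit is no longer confined to compound 1: the limit of > 50000 nM in this assay, at which 2 of the 4 values shown sit.

The exchange introduces chlorine and replaces the ethyl with a methyl at the same time, so the compounds shown do not separate the contribution of either change. On these data alone, it also remains open how this aromatic nitrogen would respond to a phenyl ring bearing an amine, a carboxylic acid or a longer chain such as propyl, and whether any such group would give a number clearly beyond the scatter from that of compound 3.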